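Acetyl removed from the ring nitrogen: a second look

This account rests on a few compounds, and the source may have more. Where it says the series, first, only, none or still open, it means among the compounds named here.

Three compounds were tested in an ADME assay on THP-1 cells (Homo sapiens) for cytotoxicity, read by flow cytometry and propidium iodide staining, with a stated time of 72 h; a lower number here means a stronger inhibitor, a higher number a weaker inhibitor. Compound 1 `COc1ccccc1-c1cc(=O)c2cc(NC(C)=O)ccc2o1` gives 50000 nM, compound 2 `COc1cccc(-c2cc(=O)c3cc(NC(C)=O)ccc3o2)c1` gives 10000 nM, and compound 3 `COc1ccccc1-c1cc(=O)c2cc(N)ccc2o1` gives 74000 nM. Compound 3 differs from compound 1 by hydrogen in place of acetyl on a nitrogen on an aromatic ring, and that change made a 1.5-fold higher number from compound 1 to compound 3 (0.17 log units; within the scatter). The difference between the cores of compound 1 and compound 2 is not broken down here. Compound 4 `COc1cccc(-c2cc(=O)c3cc(N)ccc3o2)c1` has not yet been measured in this assay; it differs from compound 2 by hydrogen in place of acetyl on a nitrogen on an aromatic ring, the same change as from compound 1 to compound 3. Because the same change made a 1.5-fold higher number from compound 1 to compound 3 (0.17 log units; within the scatter), compound 4 is expected to show a 1.5-fold higher number from compound 2 to compound 4 (0.18 log units; within the scatter). Compound 4 is therefore estimated at 15000 nM, with a likely range from 6000 nM to 40000 nM.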

Compound 4, half-maximal inhibitory concentration: > 125000 nM
Compound 4: only a limit was reported; the forecaster's own chance of this, stated with the estimate: 10%; middle value at least 8.3-fold (0.92 log units) away from the limit.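

In this assay, compound 4 gives > 125000 nM, which is a limit of the assay and not a number. On the core of compound 2, going from acetamido to amino gave an at least 12-fold higher number from compound 2 to compound 4 (1.09 log units; beyond the scatter), so the size of the step seen on the core of compound 1 did not carry over to this second core, as the two steps show: the same change on two cores in this assay, a 1.5-fold higher number (0.17 log units; within the scatter) from compound 1 to compound 3 and an at least 12-fold higher number (1.09 log units; beyond the scatter) from compound 2 to compound 4, at least 8.4-fold (0.92 log units) apart, beyond the scatter of two such steps. This shows that, for these two pairs, the effect of removing the acetyl depends on the core, but it does not show why, and the full size of the second step remains unknown.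

The compounds shown leave open whether a longer acyl chain, such as propionyl, or a methanesulfonyl group on that nitrogen would give a similar gap between the two cores. They also leave open how a third core would respond to the same change.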